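A Methoxy Swap on a Fused Core at the Assay Limit

The source may report more compounds than this note shows. Statements on the series, on what has been measured and on what is new or still open speak of the compounds shown alone.

Compound 1, `Cc1ccc2c(c1NS(C)(=O)=O)CCC2c1ncc[nH]1`, gives > 10000 nM in a functional assay on CHO cells for agonist activity at Alpha-1D adrenergic receptor (Homo sapiens), read by FLIPR and calcium flux (on this read-out higher numbers stand for an effect only at larger amounts of compound and lower numbers for an effect already at smaller amounts), and this is a limit of the assay rather than a number.
Compound 2, `Cn1cc(-c2cccc3c2CCC3c2ncc[nH]2)cn1`, gives > 10000 nM, again a limit and not a number.

Within the data shown here, compound 2 therefore stands at the edge of what the assay can report, as the limit of > 10000 nM in this assay, at which 2 of the 2 values shown sit, shows: every value measured so far sits at that same limit, so the numbers do not separate compound 2 from compound 1 in any way. The next compound, compound 3, `COc1cccc2c1CCC2c1ncc[nH]1`, has not yet been measured. It differs from compound 2 in one place: methoxy in place of 1-methyl-1H-pyrazol-4-yl on an aromatic carbon. The shared core and the imidazole-bearing part stay as they are; only the group on that aromatic carbon is exchanged.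

No measured step exists between any two of these compounds, so there is no sign of how far a change at this position moves the read-out. With both known values resting at the limit, a result beyond the scatter is not expected; the step is estimated as a step that the limit leaves unreadable from compound 2 to compound 3. Compound 3 is expected to give about 20000 nM in this assay, with a likely range from 5000 nM to 80000 nM.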

Compound 3, half-maximal effective concentration: > 10000 nM
Compound 3: no number, only a limit (the forecaster's own chance of this, stated with the estimate: 75%); the middle value lies beyond the limit too.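

No step can be read from compound 2 to compound 3, since both stand at the same limit and the swap of 1-methyl-1H-pyrazol-4-yl for methoxy has no readable size: the limit of > 10000 nM in this assay, at which 3 of the 3 values shown sit. Left open is whether any compound on this shared core gives a real number in this assay, and how far a change on this aromatic carbon can move the read-out.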